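From Compound 3 to Compound 4: Swapping One Aromatic Group

A few compounds are considered here, and "the series" means these few. Any claim that something is new, unique, unknown or untested is made for them only; others in the source may bear on it.

In a functional assay on CCRF-CEM cells (Homo sapiens) for antiproliferative activity, with a stated time of 72 h (a lower number here means a stronger inhibitor, a higher number a weaker inhibitor), compound 1 `OC[C@H]1O[C@@H](n2cnc3c(NCc4ccccc4Br)ncnc32)[C@H](O)[C@@H]1O` gives 12300 nM. Among the compounds with values here, compound 3 `OC[C@H]1O[C@@H](n2cnc3c(NCc4ccc(F)c(F)c4F)ncnc32)[C@H](O)[C@@H]1O` stands higher at 58200 nM, the highest actual number so far. For compound 2 `COc1cc(CNc2ncnc3c2ncn3[C@@H]2O[C@H](CO)[C@@H](O)[C@H]2O)cc(OC)c1` the result is > 166000 nM, which is a limit of the assay. Compound 4 `Cc1ccc(O)c(CNc2ncnc3c2ncn3[C@@H]2O[C@H](CO)[C@@H](O)[C@H]2O)c1` carries 2-hydroxy-5-methylphenyl in place of 2,3,4-trifluorophenyl on a saturated chain carbon bound to a nitrogen on an aromatic ring. Earlier swaps at this place were all beyond the scatter: a 4.7-fold higher number from compound 1 to compound 3 (0.68 log units; beyond the scatter), an at least 13-fold higher number from compound 1 to compound 2 (1.13 log units; beyond the scatter) and an at least 2.8-fold lower number from compound 2 to compound 3 (0.45 log units; beyond the scatter). They run in both directions, and none brings in this new group, so no step beyond the scatter is expected in this assay. The expected step is a 1.3-fold lower number from compound 3 to compound 4 (0.11 log units; within the scatter). For compound 4 the estimate is 45000 nM, with an expected range from 10000 nM to 170000 nM.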

Compound 4, half-maximal inhibitory concentration: 1900 nM
Compound 4: middle estimate off by 24-fold (1.37 log units), on the high side, outside the stated range (below it).
By their numbers in this assay, from the lowest: compound 4; then compound 1; then compound 3. At a limit, above all of these: compound 2.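

In this assay, this position can give a far lower number than the earlier groups did: 2-hydroxy-5-methylphenyl brings a 31-fold lower number from compound 3 to compound 4 (1.49 log units; beyond the scatter), a 6.5-fold lower number from compound 1 to compound 4 (0.81 log units; beyond the scatter) and an at least 87-fold lower number from compound 2 to compound 4 (1.94 log units; beyond the scatter). Within the data shown here, the earlier swaps from compound 1 only raised the number, so compound 4 is the first to fall below compound 1 beyond the scatter. The step from compound 2 rests on a limit, not a true number: the limit of > 166000 nM in this assay, at which 1 of the 4 values shown sits.

The compounds shown do not separate the hydroxy from the methyl of the new group. Nor do they show whether an amine in place of the hydroxy would give a similar number.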